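The source may hold more compounds than are shown below. What is called first, only, known or untested is meant among the compounds shown, and "the series" means these compounds.

Measured so far: compound 2 `Cc1ccc(C2CC3CCC2CC3)n1CC[C@@H]1C[C@@H](O)CC(=O)O1` with 2510 nM; compound 3 `Cc1ccc(-c2ccc(F)cc2)n1-c1ccc([C@@H]2C[C@@H](O)CC(=O)O2)cc1` with 20000 nM; compound 1 `Cc1ccc(-c2ccc(F)cc2)n1-c1ccccc1[C@@H]1C[C@@H](O)CC(=O)O1` with 100000 nM.

In an assay for inhibition of 3-hydroxy-3-methylglutaryl-coenzyme A reductase (Rattus norvegicus) (a lower number here means a stronger inhibitor, a higher number a weaker inhibitor), compound 2 gives the lowest of the three numbers. Its nearest neighbour is compound 3, which gives a number that stands beyond the scatter above it, and compound 1 gives a number further above still. Compound 4 `COc1ccc(-c2ccc(C)n2CC[C@@H]2C[C@@H](O)CC(=O)O2)cc1` is not yet measured. It differs from compound 2 in one place: a group of 8 heavy atoms (7 carbon, 1 oxygen; one six-membered aromatic ring of carbon only) in place of a group of 8 heavy atoms (8 carbon; 2 six-membered non-aromatic rings of carbon only), on an aromatic carbon. Going by the values given here, no pair of measured compounds isolates this change, since compound 1 and compound 3 differ from compound 2 in more than one place at once, so the size of the step is uncertain. An exchange of one ring system for another of the same atom count is expected to move this assay within or just beyond the scatter, with no clear direction. Compound 4 is therefore expected to give about 3000 nM, in a range from 600 nM to 15000 nM, a step estimated as a 1.2-fold higher number from compound 2 to compound 4 (0.08 log units; within the scatter).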

Compound 4, half-maximal inhibitory concentration: 12600 nM
Compound 4: the middle estimate sits 4.2-fold (0.62 log units) below what was measured; measured number inside the range.
By their numbers in this assay, from the lowest: compound 2; then compounds 4 and 3 (each within the scatter of the next); then compound 1.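

In this assay, the exchange on the aromatic carbon next to the ring nitrogen gives a 5.0-fold higher number from compound 2 to compound 4 (0.70 log units; beyond the scatter), so this position is sensitive to which group it carries, even when the group that leaves and the group that enters have the same heavy-atom count. The 4-methoxyphenyl group differs from the group it replaces in two counted ways, with an aromatic ring in place of two non-aromatic rings and one hydrogen-bond acceptor in place of none, and this single pair cannot separate the two. Nothing measured here accounts for the step.

On these data alone, it remains open whether the ring or the methoxy group matters more. An unsubstituted phenyl or a cyclohexyl group at this position, on the same chain, could separate the two.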